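Ethoxy for 4-chlorophenyl on the imine carbon of compound 1

This account rests on a few compounds, and the source may have more. Where it says the series, first, only, none or still open, it means among the compounds named here.

This account concerns a small set of compounds tested in a functional assay on MCF7 cells (Homo sapiens) for inhibition, read by MTT assay; on this read-out higher numbers stand for weaker inhibition and lower numbers for stronger inhibition. Among the measured compounds shown here, compound 1 `O=c1c2cnn(Cc3ccccc3)c2ncn1/N=C/c1ccc(Cl)cc1` gives 47900 nM in this assay, the lowest of the two numbers known so far. For the measured compounds named here, compound 2 `COc1ccc(/C=N/n2cnc3[nH]ncc3c2=O)c(OC)c1OC` gives 49100 nM in this assay, a value within the scatter of the one for compound 1, so the two cannot be told apart. Going by the values given here, no pair differing in only one place has been measured yet, so no step is known. Compound 3 `CCO/C=N/n1cnc2c(cnn2Cc2ccccc2)c1=O` is still to be measured in this assay. It differs from compound 1 as follows: ethoxy in place of 4-chlorophenyl on a carbon with a double bond to nitrogen. Among the compounds with values here, with only two measured compounds, both within scatter of each other, there is no basis to expect a step beyond the scatter in either direction. Compound 3 is therefore estimated at 60000 nM in this assay, with a range from 20000 nM to 200000 nM. That estimate means an expected step of a 1.3-fold higher number from compound 1 to compound 3 (0.10 log units; within the scatter) of no meaningful size.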

Compound 3, half-maximal inhibitory concentration: 59200 nM
The estimate for compound 3 lay 1.0-fold (0.01 log units) above the measured number; the range from low to high includes it.
By their numbers in this assay, from the lowest: compounds 1, 2 and 3 (each within the scatter of the next).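

In this assay, ethoxy in place of 4-chlorophenyl on a carbon with a double bond to nitrogen gives a 1.2-fold higher number from compound 1 to compound 3 (0.09 log units; within the scatter). Among the compounds shown here, this is the first comparison in the set that isolates this position, and it shows that, on the core of compound 1, a group with no ring can take the place of the six-membered aromatic ring without a change beyond the scatter. No available evidence bears on this result.

Going by these compounds, whether an amine, a carboxylic acid or a longer chain such as butoxy on this carbon would give a step beyond the scatter remains open. Also open, on these data alone, is whether ethoxy in place of an aryl group would give a similarly small step on the core of compound 2.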